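Series notes: a third methoxy group, compounds 1 to 4

This account rests on a few compounds, and the source may have more. Where it says the series, first, only, none or still open, it means among the compounds named here.

Measured so far:
compound 1, `C=C(Br)C(=O)Nc1ccc(C(=O)/C=C/c2ccc(OC)cc2)cc1`: 610 nM
compound 2, `C=C(Br)C(=O)Nc1ccc(C(=O)/C=C/c2ccc(OC)c(OC)c2)cc1`: 1800 nM
compound 3, `COc1ccc(/C=C/C(=O)c2ccc(N)cc2)c(OC)c1`: 20000 nM

In a functional assay on MOLT-4 cells (Homo sapiens) for antiproliferative activity, with a stated time of 48 h (a higher number here means a weaker inhibitor, a lower number a stronger inhibitor), compound 1 gives 610 nM and compound 2 gives 1800 nM. The change between them is methoxy in place of hydrogen on an aromatic carbon, and it made a step of a 3.0-fold higher number from compound 1 to compound 2 (0.47 log units; beyond the scatter). Compound 3 gives 20000 nM in this assay, the highest number of the three, beyond the scatter from both others. The difference between the core of compound 3 and the core of compound 1 is not broken down here.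

Compound 4, `COc1ccc(/C=C/C(=O)c2ccc(N)cc2)c(OC)c1OC`, is not yet measured in this assay. It differs from compound 3 by methoxy in place of hydrogen on an aromatic carbon. This is the same kind of change as that from compound 1 to compound 2, not the same: in compound 2 the entering methoxy is ortho to a methoxy group, in compound 4 it is ortho to two methoxy groups.

Going by the values given here, the one step of this kind, a 3.0-fold higher number from compound 1 to compound 2 (0.47 log units; beyond the scatter), went to a higher number. For compound 4 a step of similar size is therefore expected, a 2.3-fold higher number from compound 3 to compound 4 (0.35 log units; beyond the scatter). Compound 3 already sits at the top of the range, so a result near the edge of what this assay reports would not surprise. Compound 4 is expected to give about 45000 nM, between 15000 nM and 130000 nM.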

Compound 4, half-maximal inhibitory concentration: 10000 nM
Compound 4: the middle estimate sits 4.5-fold (0.65 log units) above what was measured, and the stated range ends above it.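

In this assay, the added methoxy gives a 2.0-fold lower number from compound 3 to compound 4 (0.30 log units; within the scatter), so on the core of compound 3 the change has no effect that can be told from repeat measurement, unlike the step seen on the core of compound 1. The change therefore does not carry over as a step of fixed size between these two cores: the same change on two cores in this assay, a 3.0-fold higher number (0.47 log units; beyond the scatter) from compound 1 to compound 2 and a 2.0-fold lower number (0.30 log units; within the scatter) from compound 3 to compound 4, 5.9-fold (0.77 log units) apart, beyond the scatter of two such steps. This rests on a single pair per core, and in compound 4 the entering methoxy is ortho to two methoxy groups, so the comparison does not show whether the core or the surroundings of the new group set the gap, nor how the change would behave on any other core.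

The compounds shown leave open how a hydroxyl group or a chlorine in place of the entering methoxy would read on either core. Also open, going by these compounds, is which part of the difference between the core of compound 1 and the core of compound 3 goes with the gap between the two steps.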